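Cytotoxicity notes: pentyl replaces cyclobutylcarbonyl on the ring nitrogen

The source may hold more compounds than are shown below. What is called first, only, known or untested is meant among the compounds shown, and "the series" means these compounds.

Three compounds of this series have numbers in a functional assay on WI-38 VA13 cells (Homo sapiens) for cytotoxicity; on this read-out higher numbers stand for an effect only at larger amounts of compound and lower numbers for an effect already at smaller amounts. Compound 1 `Cn1ncc([N+](=O)[O-])c1C(=O)Nc1ccc2nc(NC(=O)C3CCCCC3)sc2c1` gives 0.026 ug/mL, compound 2 `O=C(Nc1nc2ccc(N/C(S)=N/c3ccccc3OC(F)(F)F)cc2s1)C1CCCCC1` gives 2.3 ug/mL, and compound 3 `O=C(Nc1ccc2nc(NC(=O)C3CCC3)sc2c1)c1c(Cl)cccc1Cl` gives 0.013 ug/mL. Compound 3 has the lowest of the three numbers, but its gap to compound 1 lies within the usual scatter, so the two cannot be placed in order; only compound 2 stands clearly apart from compound 3, beyond the scatter.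

Compound 4 `CCCCCNc1nc2ccc(NC(=O)c3c(Cl)cccc3Cl)cc2s1` is not yet measured in this assay. It differs from compound 3 in one place: pentyl in place of cyclobutylcarbonyl on a nitrogen on an aromatic ring. Cut one bond further out, the change reads (cyclobutylcarbonyl)amino to pentylamino, on a nitrogen on an aromatic ring whose other neighbour is an aromatic carbon. For the measured compounds named here, no measured pair in the set shows this change, so its effect is not known from the data.

Going by the values given here, the expectation is a moderate rise in the number, beyond the scatter, since the only compound without an acyl group on that ring nitrogen in the set is compound 2 at 2.3 ug/mL, though compound 2 changes several places at once. For compound 4 the estimate in this assay is 0.05 ug/mL, with a range from 0.012 ug/mL to 0.25 ug/mL. The step this estimate means is expected at a 3.8-fold higher number from compound 3 to compound 4 (0.59 log units; beyond the scatter).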

Compound 4, half-maximal effective concentration: 0.27 ug/mL
Compound 4: the middle estimate sits 5.4-fold (0.73 log units) below what was measured; measured number outside the range, above it.
By their numbers in this assay, from the lowest: compounds 3 and 1 (each within the scatter of the next); then compound 4; then compound 2.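

In this assay, for the compounds shown here, pentyl in place of cyclobutylcarbonyl on a nitrogen on an aromatic ring gives a 21-fold higher number from compound 3 to compound 4 (1.32 log units; beyond the scatter), the first reading of this position with only one place changed. The position is therefore not indifferent to its substituent: with the 2,6-dichlorobenzamide side of compound 3 held constant, this change alone moves the number well beyond the scatter. The change removes the carbonyl and the four-membered ring together, so this single pair cannot show which of the two accounts for the step, and no available data explain it.

Still open, going by these compounds, is whether pentanoyl, which keeps the carbonyl without the ring, or cyclobutyl directly on the nitrogen, which keeps the ring without the carbonyl, would stand nearer to compound 3 or to compound 4. On these data alone, it is also open whether a shorter chain, a longer chain or a chain ending in an amine would behave like pentyl, and whether the same change would give a step of similar size with the remainder of compound 1.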